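Changing the Dimethylamino Group of Compound 3

The source may hold more compounds than are shown below. What is called first, only, known or untested is meant among the compounds shown, and "the series" means these compounds.

In an ADME assay for permeability, using PAMPA, with a stated time of 4 h, at pH 7.4 (a lower number here means that the compound crosses the layer more slowly, a higher number that the compound crosses the layer faster), compound 3 (`CN(C)CCCCN(C[C@H]1Cc2ncccc2CN1)[C@H]1CCCc2cccnc21`) sits highest at 240 nm/s and well clear of compound 1 (`NC/C=C/CN(C[C@H]1Cc2ncccc2CN1)[C@H]1CCCc2cccnc21`) at 15 nm/s and compound 2 (`NC(=O)NC/C=C/CN(C[C@H]1Cc2ncccc2CN1)[C@H]1CCCc2cccnc21`) at 2 nm/s as the lowest of the three. Compound 4 (`c1cnc2c(c1)CN[C@@H](CN(CCCCNC1CCOCC1)[C@H]1CCCc3cccnc31)C2`) has no number yet. It differs from compound 3 on a saturated chain carbon, four bonds along the chain from an amine nitrogen ((oxan-4-yl)amino in place of dimethylamino on a saturated chain carbon, four bonds along the chain from an amine nitrogen).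

Among the measured compounds shown here, no measured step makes this exact swap. The closest guides are one large step (a 16-fold higher number from compound 1 to compound 3 (1.20 log units; beyond the scatter)) and one modest step (a 7.5-fold lower number from compound 1 to compound 2 (0.88 log units; beyond the scatter)), and both change more than this single group, so they guide only loosely. Compound 1 and compound 2 keep a hydrogen on the nitrogen of the changing group, as compound 4 does, while compound 3 (240 nm/s) has none there. In this assay a moderate fall is therefore expected (a 3.4-fold lower number from compound 3 to compound 4 (0.54 log units; beyond the scatter)). The estimate for compound 4 is 70 nm/s with an expected span from 20 nm/s to 220 nm/s as its range.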

Compound 4, apparent permeability: 8 nm/s
Compound 4: the middle estimate sits 8.8-fold (0.94 log units) above what was measured; measured number outside the range, below it.
By their numbers in this assay, from the lowest: compound 2; then compounds 4 and 1 (each within the scatter of the next); then compound 3.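

In this assay, this assay, the group at the end of the chain carries great weight: (oxan-4-yl)amino in place of dimethylamino, with nothing else changed, gives the largest fall yet seen for a single group (a 30-fold lower number from compound 3 to compound 4 (1.48 log units; beyond the scatter)). Compound 4 still stays clear of compound 2 (a 4.0-fold higher number from compound 2 to compound 4 (0.60 log units; beyond the scatter)), although that pair differs by a larger stretch of the chain. Compound 4 and compound 1 cannot be told apart (a 1.9-fold lower number from compound 1 to compound 4 (0.27 log units; within the scatter)), even though their chains differ in length, saturation and end group.

Nothing measured here accounts for the fall. A methylamino group would keep the hydrogen on the nitrogen without the ring, and methyl(oxan-4-yl)amino would keep the ring without that hydrogen, so either could help separate the two changes made together in compound 4.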